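Swapping fluoro for isopropyl on the shared core

A few compounds are considered here, and "the series" means these few. Any claim that something is new, unique, unknown or untested is made for them only; others in the source may bear on it.

Within the data shown here, in a functional assay on MCF7 cells (Homo sapiens) for antiproliferative activity, with a stated time of 5 days (on this read-out lower numbers stand for stronger inhibition and higher numbers for weaker inhibition), compound 1 `COc1ccc(-c2[nH]c3ccc(F)cc3c2C=O)cc1` gives 240 nM, the higher of the two numbers measured so far. Compound 2 `COc1ccc(-c2[nH]c3cc(Cl)c(C)cc3c2C=O)cc1`, which is substituted differently on the shared core, gives 62 nM, and this gap lies beyond the usual scatter of repeated measurements. Compound 3 `COc1ccc(-c2[nH]c3ccc(C(C)C)cc3c2C=O)cc1` has not yet been measured. It differs from compound 1 in one place, with isopropyl in place of fluoro on an aromatic carbon. Among the measured compounds shown here, no measured pair shows what a change at this place does, so the data offer no direct guide. A step beyond the scatter is not expected, and neither direction can be favoured with confidence. The estimated step is a 1.2-fold lower number from compound 1 to compound 3 (0.08 log units; within the scatter). For compound 3, the expected value is 200 nM, with an estimated range of 50 nM to 900 nM.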

Compound 3, half-maximal inhibitory concentration: 97 nM
The estimate for compound 3 lay 2.1-fold (0.31 log units) above the measured number; the range from low to high includes it.
By their numbers in this assay, from the lowest: compounds 2 and 3 (each within the scatter of the next); then compound 1.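

Among these compounds, this is the first step seen at this position of the shared core. In this assay, isopropyl in place of fluoro gives a 2.5-fold lower number from compound 1 to compound 3 (0.39 log units; beyond the scatter), a modest change, so the number does respond to the group on this aromatic carbon, and the larger count of heavy atoms in isopropyl comes with stronger inhibition rather than a loss of it. No supporting measurement explains why the number moves. On these data alone, only fluoro and isopropyl appear at this position here, so it remains open whether an amine, a carboxylic acid or a longer chain would push the number further in the same direction or reverse it. Compound 2 differs from compound 1 in more than one place, which leaves open whether the same swap would give a similar step on a differently substituted core.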